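Compound 3: Methylpiperazine Replaces Pyrrolidine

This account rests on a few compounds, and the source may have more. Where it says the series, first, only, none or still open, it means among the compounds named here.

Of the compounds shown here, two sharing one core have been measured in a functional assay on PC-3 cells (Homo sapiens) for cytotoxicity, read by MTT assay, with a stated time of 48 h; on this read-out lower numbers stand for stronger inhibition and higher numbers for weaker inhibition. Compound 1 `CC(C)CNCC(=O)N1N=C(c2cc3ccccc3oc2=O)CC1c1ccccc1` gives 1920 nM in this assay, and compound 2 `O=C(CN1CCCC1)N1N=C(c2cc3ccccc3oc2=O)CC1c1ccccc1` gives 50200 nM. Going by the values given here, the one step between them, a 26-fold higher number from compound 1 to compound 2 (1.42 log units; beyond the scatter), leaves compound 2 at the highest number of the two, with compound 1 as its nearest neighbour at a clearly lower value.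

Compound 3 `CN1CCN(CC(=O)N2N=C(c3cc4ccccc4oc3=O)CC2c2ccccc2)CC1` differs from compound 2 in one place: 4-methylpiperazin-1-yl in place of pyrrolidin-1-yl on a saturated chain carbon bound to a carbonyl carbon. Among the compounds with values here, no measured step bears directly on this exchange. Within the data shown here, the only step available, a 26-fold higher number from compound 1 to compound 2 (1.42 log units; beyond the scatter), compares isobutylamino with pyrrolidin-1-yl at the same place, whereas here one ring group gives way to another ring group. With nothing in the data pointing either way, compound 3 is expected to remain close to compound 2, and the estimated step of a 1.7-fold lower number from compound 2 to compound 3 (0.22 log units; within the scatter) is one that would fall within the scatter of this assay. The estimate for compound 3 in this assay is 30000 nM, with a range from 8000 nM to 120000 nM.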

Compound 3, half-maximal inhibitory concentration: 25800 nM
The estimate for compound 3 lay 1.2-fold (0.07 log units) above the measured number, and the stated range covers the measured number.
By their numbers in this assay, from the lowest: compound 1; then compounds 3 and 2 (each within the scatter of the next).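

In this assay, the exchange at the saturated chain carbon bound to a carbonyl carbon gives a 1.9-fold lower number from compound 2 to compound 3 (0.29 log units; within the scatter) and so does not tell the six-membered 4-methylpiperazin-1-yl ring, with its two hetero atoms, from the five-membered pyrrolidin-1-yl ring. The gap opened by the earlier step is therefore not peculiar to pyrrolidin-1-yl: with a 13-fold higher number from compound 1 to compound 3 (1.13 log units; beyond the scatter) as the second ring group's result, both ring groups stand well apart from isobutylamino, and among these three compounds only compound 1, the one carrying isobutylamino, reaches the low end of the range, with none of the three going against this. Nothing measured here gives a reason for this pattern.

The compounds shown leave open whether the low number belongs to isobutylamino alone or is shared by other open-chain groups at this place, such as an n-butylamino, a diethylamino or a cyclopropylmethylamino group. They also leave open whether a ring without a second basic nitrogen, such as morpholin-4-yl, or a wider ring such as piperidin-1-yl, would stay with compound 2 and compound 3 or move toward compound 1.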